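The compounds below may be only part of what the source reports. "The series", "measured", "known", "first", "only" and "open" are said of these compounds alone.

Measured so far in an assay on isolated protein for inhibition of Amine oxidase [flavin-containing] B (Homo sapiens), read by spectrophotometry; a lower number here means a stronger inhibitor, a higher number a weaker inhibitor:
compound 1 `COc1ccc(/C=N/Nc2nc3ccccc3nc2Cc2ccccc2)cc1OC` gives 460000 nM
compound 2 `Clc1ccccc1/C=N/Nc1nc2ccccc2nc1Cc1ccccc1` gives 87000 nM
compound 3 `CN(C)c1ccc(/C=N/Nc2nc3ccccc3nc2Cc2ccccc2)cc1` gives 880000 nM

All three share one core and differ only in the aryl group on the carbon carrying the double bond to nitrogen. Compound 3 holds the highest number of the three: against compound 1 the gap is within the scatter, against compound 2 it is beyond it, as the step of a 10-fold higher number from compound 2 to compound 3 (1.00 log units; beyond the scatter) shows. The step of a 5.3-fold lower number from compound 1 to compound 2 (0.72 log units; beyond the scatter) is the other change beyond the scatter; a 1.9-fold higher number from compound 1 to compound 3 (0.28 log units; within the scatter) is not.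

Compound 4 `O=[N+]([O-])c1ccc(/C=N/Nc2nc3ccccc3nc2Cc2ccccc2)cc1` is not yet measured. It differs from compound 3 by nitro in place of dimethylamino on an aromatic carbon. For the measured compounds named here, no measured step touches a nitro group, so the bearing of the earlier steps is only that changing this aryl moves this assay by modest amounts, with the smallest numbers where the aryl carries a halogen rather than a donor group. A modest move toward a lower number is therefore expected, estimated as a 2.9-fold lower number from compound 3 to compound 4 (0.47 log units; beyond the scatter). For compound 4 the expected value in this assay is 300000 nM, with a range of 80000 nM to 1000000 nM.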

Compound 4, half-maximal inhibitory concentration: 960000 nM
Estimate against measurement, compound 4: 3.2-fold (0.51 log units) below; measured number inside the range.
By their numbers in this assay, from the lowest: compound 2; then compounds 1, 3 and 4 (each within the scatter of the next, the first and the last beyond it).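

In this assay, 4-nitrophenyl and 4-(dimethylamino)phenyl cannot be told apart at this position (a 1.1-fold higher number from compound 3 to compound 4 (0.04 log units; within the scatter)), although the two groups share only a single nitrogen among their heavy atoms. Among the four aryl groups, 2-chlorophenyl remains the one clearly separated from the rest (an 11-fold higher number from compound 2 to compound 4 (1.04 log units; beyond the scatter)), while the gap to 3,4-dimethoxyphenyl is much smaller (a 2.1-fold higher number from compound 1 to compound 4 (0.32 log units; beyond the scatter)). No available evidence bears on why nitro and dimethylamino read alike here.

The compounds shown leave open whether the lower number of compound 2 belongs to the chlorine itself or to where it sits on the ring. A 4-chlorophenyl group, a 2-nitrophenyl group and an unsubstituted phenyl group would separate these readings.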